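The source may hold more compounds than are shown below. What is called first, only, known or untested is meant among the compounds shown, and "the series" means these compounds.

Working notes on the step from compound 1 to compound 4. In an ADME assay on Huh7.5.1 cells (Homo sapiens) for cytotoxicity, read by ATP content, with a stated time of 48 h (a lower number here means that less compound is tolerated, a higher number that more compound is tolerated), compound 1 `Cc1oc(-c2c(C)c(C)c(C)c(C)c2C)nc1CN1CCC(C(=O)NCCCN2C[C@H](C)C[C@H](C)C2)CC1` gives 8180 nM, within the scatter of compound 2 `Cc1ccccc1-c1nc(CN2CCC(C(=O)NCCCN3CCC(C(C)C)CC3)CC2)c(C)o1` at 4280 nM. Compound 3 `Cc1ccccc1-c1nc(CN2CCC(C(=O)NCCCN3[C@H](C)CCC[C@@H]3C)CC2)c(C)o1` gives 21300 nM, a higher number than either, beyond the scatter in both cases.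

The next compound to be read is compound 4 `Cc1oc(-c2c(Cl)cccc2Br)nc1CN1CCC(C(=O)NCCCN2C[C@H](C)C[C@H](C)C2)CC1`. Its change from compound 1 is 2-bromo-6-chlorophenyl in place of 2,3,4,5,6-pentamethylphenyl on an aromatic carbon.

For the measured compounds named here, the only measured single-place step, a 5.0-fold higher number from compound 2 to compound 3 (0.70 log units; beyond the scatter), is modest, but it concerns the piperidinyl group and not the group exchanged here. Going by the values given here, it therefore shows only that a one-place change can move this assay beyond the scatter. Among the compounds with values here, no measured step covers the exchanged group, so neither direction is supported, and no step beyond the scatter is expected. The step expected is a 1.0-fold higher number from compound 1 to compound 4 (0.02 log units; within the scatter).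

For compound 4 the estimated value is 8500 nM, with an expected range of 3500 nM to 21000 nM.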

Compound 4, half-maximal cytotoxic concentration: 12200 nM
Estimate against measurement, compound 4: 1.4-fold (0.16 log units) below, and the stated range covers the measured number.
By their numbers in this assay, from the lowest: compounds 2, 1, 4 and 3 (each within the scatter of the next, the first and the last beyond it).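

In this assay, the first single-place change read at this position, on an aromatic carbon of the five-membered aromatic ring, gives a 1.5-fold higher number from compound 1 to compound 4 (0.17 log units; within the scatter) and so stays within the scatter. The two groups differ in their substituents and in size, 2,3,4,5,6-pentamethylphenyl with 11 heavy atoms and 2-bromo-6-chlorophenyl with 8 heavy atoms including chlorine and bromine, yet this exchange leaves the number where repeat measurements could place it. No measurement shown offers a reason for this result.

As far as these compounds go, whether a phenyl bearing an amine or a carboxylic acid, or an unsubstituted phenyl, at this position would move the number beyond the scatter stays open. Also open, from the compounds shown here alone, is whether 2,6-dimethylpiperidin-1-yl on the chain would give a similar step alongside 2-bromo-6-chlorophenyl.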